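The compounds below may be only part of what the source reports. "The series", "measured", "known", "first", "only" and "open" are said of these compounds alone.

Measured compounds:
- compound 1, `CC(C)COc1ccc2c(Cl)ccnc2c1`: 2490 nM
- compound 2, `Fc1ccc(COc2ccc3c(Cl)ccnc3c2)cc1`: 2070 nM
- compound 3, `CCOc1ccc2c(NCCN(C)C)ccnc2c1`: 2570 nM

All three were tested in a functional assay on HCT-116 cells (Homo sapiens) for cytotoxicity, read by MTT assay, with a stated time of 48 h; a lower number here means a stronger inhibitor, a higher number a weaker inhibitor. Compound 1 gives 2490 nM in this assay, the second highest of the three numbers; compound 3 sits nearest with 2570 nM, and compound 2 lies furthest with 2070 nM. Both of those gaps fall inside the usual scatter of repeated measurements, so the three compounds cannot be told apart on these numbers, and none can be called the stronger or the weaker.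

The next compound, compound 4, `CCCCOc1ccc2c(Cl)ccnc2c1`, has not yet been measured in this assay. It differs from compound 1 in a single place: propyl in place of isopropyl on a saturated chain carbon bound to an oxygen on an aromatic ring. The two compounds contain the same atoms, joined differently; the chain is straightened rather than lengthened or exchanged for something else.

Among the compounds with values here, no measured pair in this set shows what such a rearrangement of the chain does, so there is nothing here to point in either direction. With compound 1 giving 2490 nM, the expectation is that the step of a 1.0-fold higher number from compound 1 to compound 4 (0.00 log units; within the scatter) stays within the scatter. Compound 4 is therefore estimated at 2500 nM in this assay, within a range from 1200 nM to 5200 nM.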

Compound 4, half-maximal inhibitory concentration: 2740 nM
For compound 4 the middle estimate is 1.1-fold (0.04 log units) below the measured one, and the stated range covers the measured number.
By their numbers in this assay, from the lowest: compounds 2, 1, 3 and 4 (each within the scatter of the next).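

Within the data shown here, compounds 1 and 4 form the first pair in this set that differs in one place only, so the effect of a change at this position can now be read directly rather than guessed. In this assay, propyl in place of isopropyl on a saturated chain carbon bound to an oxygen on an aromatic ring gives a 1.1-fold higher number from compound 1 to compound 4 (0.04 log units; within the scatter) and so leaves the two compounds indistinguishable: for this one pair, the branched isobutoxy and the straight butoxy, built from the same atoms, show no readable difference. Nothing measured here offers an explanation for this result.

This single pair tests only a rearrangement of the chain, so it leaves open whether a real change in the group at this place, such as a much shorter chain, a longer chain, an amine or a carboxylic acid, would move the number beyond the scatter. It also leaves open whether straightening the chain would read the same way in this assay on a core carrying a different group elsewhere.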